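Heteroaryl Amide in Place of Cyclopropyl Amide

This account rests on a few compounds, and the source may have more. Where it says the series, first, only, none or still open, it means among the compounds named here.

Measured compounds:
- compound 1 `O=C1NCCc2nc(C#Cc3ccccc3)sc21`: 112 nM
- compound 2 `Fc1cccc(C#Cc2nc3c(s2)CN(C2CCC2)CC3)c1`: > 10000 nM
- compound 3 `CC1CC1C(=O)N1CCc2nc(C#Cc3ccccc3)sc2C1`: 9.4 nM

The three measured compounds share a core that carries a phenyl-bearing alkyne and differ in what sits on the ring nitrogen. In an assay on HEK293 cells for positive allosteric modulation of metabotropic glutamate receptor 5 (Homo sapiens), read by FLIPR, with a stated time of 1 h (on this read-out higher numbers stand for an effect only at larger amounts of compound and lower numbers for an effect already at smaller amounts), compound 1, whose ring nitrogen carries only a hydrogen on an amide, gives 112 nM. Compound 2 carries a cyclobutyl group on that nitrogen and returns only a limit of this assay, > 10000 nM, which is not a number. Compound 3, with a (2-methylcyclopropyl)carbonyl on the ring nitrogen, gives 9.4 nM and thus stands lowest of the two numbers shown; compound 1 is its nearest neighbour, and the gap between them lies beyond the usual scatter.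

Compound 4 `Cc1nc(C(=O)N2CCc3nc(C#Cc4ccccc4)sc3C2)cs1` has not yet been measured in this assay. It differs from compound 3 in one place:

2-methyl-1,3-thiazol-4-yl in place of 2-methylcyclopropyl on a carbonyl carbon

Among the measured compounds shown here, no pair of measured compounds shows this kind of exchange, so the direction of the step rests on expectation alone. The amide carbonyl on the ring nitrogen is kept, and only the group on that carbonyl carbon changes, so a modest shift is expected rather than a large one. Compound 4 is expected to give about 20 nM in this assay, within a range of 5 nM to 80 nM. The step this implies, a 2.1-fold higher number from compound 3 to compound 4 (0.33 log units; beyond the scatter), is estimated to lie close to the edge of the scatter.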

Compound 4, half-maximal effective concentration: 220 nM
Compound 4: middle estimate off by 11-fold (1.04 log units), on the low side; measured number above the stated range.
By their numbers in this assay, from the lowest: compound 3; then compounds 1 and 4 (each within the scatter of the next). At a limit, above all of these: compound 2.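

In this assay, the group on the carbonyl carbon turns out to matter a great deal: with the amide kept, exchanging 2-methylcyclopropyl for 2-methyl-1,3-thiazol-4-yl gives a 23-fold higher number from compound 3 to compound 4 (1.37 log units; beyond the scatter). Before this pair, no two measured compounds differed in only one place, so the contribution of this group could not be separated from the rest of the structure. In this pair, a five-membered aromatic ring with 2 hetero atoms and 2 hydrogen-bond acceptors takes the place of a three-membered ring of carbon only, and the compound with the small carbon ring needs far less compound for an effect.

This single step cannot show which part of the exchange accounts for the higher number, and nothing measured here gives a reason for it. Going by these compounds, it remains open whether a plain phenyl ring, an unsubstituted cyclopropyl group or a longer chain such as n-butyl on the same carbonyl carbon would give a number close to that of compound 3 or one close to that of compound 4.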